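From Methoxyphenyl to Chloro Ester in Cytotoxicity

The source may report more compounds than this note shows. Statements on the series, on what has been measured and on what is new or still open speak of the compounds shown alone.

In a functional assay on HCT-116 cells (Homo sapiens) for cytotoxicity, read by sulforhodamine B assay, with a stated time of 72 h (a lower number here means a stronger inhibitor, a higher number a weaker inhibitor), compound 2 `CCS(=O)(=O)Nc1cc(-c2ccc3ncnc(Nc4ccc(OC)cc4)c3c2)cnc1OC` gives 3490 nM as its value, while compound 3 `CCS(=O)(=O)Nc1cc(-c2ccc3ncnc(Nc4ccc(OC)c(Cl)c4)c3c2)cnc1OC` gives 5620 nM and so sits within the scatter of it. Compound 1 `CCS(=O)(=O)Nc1cc(-c2ccc3ncnc(Nc4ccc(OC(F)(F)F)cc4)c3c2)cnc1OC` stands apart at 16600 nM and is the only clear outlier of the three.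

Compound 4 `CCS(=O)(=O)Nc1cc(-c2ccc3ncnc(Nc4ccc(Cl)c(C(=O)OC)c4)c3c2)cnc1OC` has 4-chloro-3-(methoxycarbonyl)phenyl in place of 4-methoxyphenyl on a nitrogen on an aromatic ring on the shared core. The closest guide is the addition of chloro, a 1.6-fold higher number from compound 2 to compound 3 (0.21 log units; within the scatter), which is small. The exchanges that removed the 4-(trifluoromethoxy)phenyl group were larger, at a 4.8-fold lower number from compound 1 to compound 2 (0.68 log units; beyond the scatter) and a 3.0-fold lower number from compound 1 to compound 3 (0.47 log units; beyond the scatter), so changes on this ring have moved the number by modest amounts. Within the data shown here, no measured compound carries a methoxycarbonyl group, which leaves the direction uncertain.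

A small rise is expected, an estimated 2.0-fold higher number from compound 2 to compound 4 (0.30 log units; within the scatter) in this assay. For compound 4 the estimated value is 7000 nM within an expected range of 2500 nM to 20000 nM.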

Compound 4, half-maximal inhibitory concentration: 3130 nM
Compound 4: middle estimate off by 2.2-fold (0.35 log units), on the high side; the range from low to high includes it.
By their numbers in this assay, from the lowest: compounds 4, 2 and 3 (each within the scatter of the next); then compound 1.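

Among these compounds, the methoxycarbonyl group appears here for the first time, and in this assay it brings no clear shift: exchanging 4-methoxyphenyl for 4-chloro-3-(methoxycarbonyl)phenyl on the nitrogen gives a 1.1-fold lower number from compound 2 to compound 4 (0.05 log units; within the scatter). The exchange from 3-chloro-4-methoxyphenyl gives a 1.8-fold lower number from compound 3 to compound 4 (0.25 log units; within the scatter), so this position accepts a larger group with a different substitution pattern while the number stays within the scatter of both compounds. The 4-(trifluoromethoxy)phenyl group remains the one that stands apart, now with a 5.3-fold lower number from compound 1 to compound 4 (0.72 log units; beyond the scatter).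

No supporting measurement bears on why these compounds group as they do. The compounds shown also leave the chloro and methoxycarbonyl parts unseparated, and leave open how a carboxylic acid or an amide in place of the methoxycarbonyl group would read.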